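From Trifluoromethyl to Methyl on a Shared Core

The source may hold more compounds than are shown below. What is called first, only, known or untested is meant among the compounds shown, and "the series" means these compounds.

Measured so far:
Compound 1, `COc1cc(O)cc(O)c1C(=O)/C=C/c1ccc(C(F)(F)F)cc1`: 17100 nM
Compound 2, `C=CCOc1cc(OC)c(C(=O)/C=C/c2ccccc2F)c(OCC=C)c1`: 13300 nM
Compound 3, `COc1cc(/C=C/C(=O)c2c(O)cc(O)cc2OC)ccc1O`: "not determined" (no result reported)

In a toxicity assay on cells (Macrophage, Mus musculus, strain BALB/c) for cytotoxicity, read by MTT assay (a lower number here means a stronger inhibitor, a higher number a weaker inhibitor), compound 1 gives 17100 nM. For the measured compounds named here, only one other compound carries a number in this assay: compound 2 gives 13300 nM. Going by the values given here, of these two numbers the one from compound 1 is the larger, but the gap between them lies within the scatter of repeated measurements, so the two compounds cannot be told apart on this evidence. Compound 3 is reported in this assay as "not determined" (no result reported), so nothing can be said of it.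

The new compound is compound 4, `COc1cc(O)cc(O)c1C(=O)/C=C/c1ccc(C)cc1`. It keeps the core of compound 1 and differs in one place: methyl in place of trifluoromethyl on an aromatic carbon. Among the compounds with values here, no measured pair shows this change, so its effect is unknown here.

With no guide from the data, the expected step from compound 1 to compound 4 in this assay is a small one, a 1.2-fold higher number from compound 1 to compound 4 (0.07 log units; within the scatter), not beyond the scatter in either direction. Compound 4 is therefore estimated to give 20000 nM in this assay, with an expected range from 8000 nM to 50000 nM.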

Compound 4, half-maximal inhibitory concentration: 16500 nM
Estimate against measurement, compound 4: 1.2-fold (0.08 log units) above; the measured number falls inside the stated range.
By their numbers in this assay, from the lowest: compounds 2, 4 and 1 (each within the scatter of the next).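

For the compounds shown here, on the shared core, this is the first measured pair that isolates a single change at this position: in this assay, methyl in place of trifluoromethyl on an aromatic carbon, para to a large group, gives a 1.0-fold lower number from compound 1 to compound 4 (0.02 log units; within the scatter) and so does not separate the two compounds. The swap replaces a group of 4 heavy atoms, including 3 fluorine atoms, with a group of 1 heavy atom, yet this reading of cell toxicity cannot tell the two apart. Nothing shown here offers an explanation for this result.

Going by these compounds alone, the pair covers only two small groups that carry no hydrogen-bond donors or acceptors and no net charge, so it cannot show whether this position tolerates every replacement in the same way. An amine, a carboxylic acid or a longer carbon chain in the same place remains an open test, and only such a group could show whether a different kind of substituent here moves the number beyond the scatter of repeated measurements.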